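A few compounds are considered here, and "the series" means these few. Any claim that something is new, unique, unknown or untested is made for them only; others in the source may bear on it.

Measured compounds:
- compound 1, `O=C(O)c1cc(-c2ccc(-c3ccc(F)c(Cl)c3)cc2)n(-c2ccc(Cl)cc2Cl)n1`: 20900 nM
- compound 2, `O=C(O)Cn1nc(C(=O)O)cc1-c1ccc(-c2ccc(Cl)cc2Cl)cc1`: 100000 nM
- compound 3, `O=C(O)c1cc(-c2ccc(-c3ccc(Cl)cc3Cl)cc2)nn1Cc1ccccn1`: 22300 nM

Of the compounds shown here, three sharing the same core have been measured in an assay on isolated protein for inhibition of methionine--tRNA ligase, cytoplasmic (Homo sapiens); a higher number here means a weaker inhibitor, a lower number a stronger inhibitor. Compound 1 gives the lowest number of the three; its nearest neighbour is compound 3, whose value lies within the scatter of that of compound 1, so no order between these two can be drawn. Compound 2 sits furthest away, with a number beyond the scatter above compound 1. Within the data shown here, since no two of the measured compounds differ in only one place, no step in this assay has been resolved so far.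

Compound 4, `O=C(O)c1cc(-c2ccc(-c3ccc(C(F)(F)F)cc3)cc2)n(-c2ccc(Cl)cc2Cl)n1`, has not yet been measured. Relative to compound 1 the change is 4-(trifluoromethyl)phenyl in place of 3-chloro-4-fluorophenyl on an aromatic carbon. The new group enters on an aromatic carbon of a six-membered aromatic ring of carbon only, para to a large group. Among the measured compounds shown here, nothing among the measured compounds shows what an exchange of this kind does in this assay, so no direction can be read from the data. The expectation is therefore a step from compound 1 to compound 4 of a 1.2-fold higher number from compound 1 to compound 4 (0.08 log units; within the scatter), which is taken as no step beyond the scatter. On that basis compound 4 is estimated at 25000 nM, with a range from 8000 nM to 80000 nM.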

Compound 4, half-maximal inhibitory concentration: 33500 nM
The estimate for compound 4 lay 1.3-fold (0.13 log units) below the measured number; the measured number falls inside the stated range.
By their numbers in this assay, from the lowest: compounds 1, 3 and 4 (each within the scatter of the next); then compound 2.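

In this assay, among these compounds, the exchange of 3-chloro-4-fluorophenyl for 4-(trifluoromethyl)phenyl on an aromatic carbon gives a 1.6-fold higher number from compound 1 to compound 4 (0.20 log units; within the scatter) and is the first step that can be read at all. No order can be drawn between the two compounds, so at this place, para to a large group, the one halogen-bearing ring and the other are not told apart by this assay. Nothing measured here bears on why the two groups give numbers within the scatter of each other.

As far as these compounds go, it remains open whether a group of a different kind on this aromatic carbon, such as an amine, a carboxylic acid or a plain unsubstituted phenyl ring, would give a step beyond the scatter. It is also open what any single change elsewhere on the shared core does, as compound 2 and compound 3 each differ from every other compound shown in more than one place.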